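Chain Extension on the Ether of a Pyrazole Amide Series

This account rests on a few compounds, and the source may have more. Where it says the series, first, only, none or still open, it means among the compounds named here.

Measured so far:
compound 1 `CCOc1cc(C(=O)N(C)C)nn1-c1ccccc1` — 65.8%
compound 2 `CCCCOc1cc(C(=O)NC(C)C)nn1-c1ccccc1` — 15.8%

In a functional assay on the whole organism (strain Wistar) for inhibition, with Rattus norvegicus as the target, read by paw edema, with stated times of 30 min and 3 h, at a dose of 100 mg/kg by the oral route (on this read-out higher numbers stand for more inhibition at the one dose given (going by the name of the read-out) and lower numbers for less inhibition), compound 1 gives 65.8%, the higher of the two numbers; compound 2, with 15.8%, lies far below it, beyond the scatter. For the measured compounds named here, compound 2 differs from compound 1 in two places at once, so the two values show only that the pair spans a wide gap, not which change carries it.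

Compound 3 `CC(C)CCOc1cc(C(=O)N(C)C)nn1-c1ccccc1` differs from compound 1 in one place: isopropyl in place of hydrogen on a saturated chain carbon, two bonds along the chain from an oxygen on an aromatic ring. Read one bond further out, this is ethoxy to isopentyloxy. Going by the values given here, no single-point step between measured compounds is known. A moderate downward step a number 25.8 percentage points lower from compound 1 to compound 3 (beyond the scatter) is expected, since compound 2 with its longer ether gives 15.8%. Compound 3 is estimated at 40%, expected within 15% to 65%.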

Compound 3, a percentage reported as inhibition, in the whole organism at one dose (the size of the read-out at that dose, not a potency): 25.3%
Estimate against measurement, compound 3: 14.7 percentage points above; the range from low to high includes it.
By their numbers in this assay, from the lowest: compounds 2 and 3 (each within the scatter of the next); then compound 1.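

In this assay, ethoxy to isopentyloxy with the amide held fixed reads as a number 40.5 percentage points lower from compound 1 to compound 3 (beyond the scatter). The ether chain therefore moves this read-out on its own, a single-place result that the pair of compound 1 and compound 2, differing in two places, could not give. Nothing measured here bears on the reason for this step. Open, on these data alone, is whether the loss follows the length of the chain or its branch. An unbranched pentyloxy chain on the core of compound 1 would separate the two, and a methoxy ether would show the shorter side.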